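This account rests on a few compounds, and the source may have more. Where it says the series, first, only, none or still open, it means among the compounds named here.

Compounds measured so far:

compound 1, `COc1ccccc1NCC(=O)Oc1ccc2c(C)cc(=O)oc2c1`, 15.3%
compound 2, `Cc1cc(=O)oc2cc(OC(=O)CNc3ccccc3[N+](=O)[O-])ccc12`, 16.6%
compound 3, `Cc1cc(=O)oc2cc(OC(=O)CNc3nc4ccccc4s3)ccc12`, 35.9%

The three compounds share one core and differ only in the group attached to the aminoacetate nitrogen. In a functional assay on the whole organism (strain Wistar albino) for inhibition, with Rattus norvegicus as the target, read by paw edema, with stated times of 30 min and 2 h, at a dose of 20 mg/kg by the oral route (on this read-out higher numbers stand for more inhibition at the one dose given (going by the name of the read-out) and lower numbers for less inhibition), compound 1 gives the lowest of the three numbers. Compound 2 lies nearest to it, and the two values lie within the scatter of each other, so no order between them can be drawn. Compound 3 lies furthest, with a value beyond the scatter above that of compound 1.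

The new compound, compound 4 with `Cc1cc(=O)oc2cc(OC(=O)CNc3ccccc3Cl)ccc12`, arises from compound 1 by one change: chloro in place of methoxy on an aromatic carbon.

Within the data shown here, only one measured step bears on this change, the exchange of the same group at the same aromatic carbon on going from compound 1 to compound 2: a number 1.3 percentage points higher from compound 1 to compound 2 (within the scatter). Since that replacement of methoxy left the read-out unchanged within the scatter, the expectation for the chloro replacement is likewise no step beyond the scatter. Compound 4 is therefore estimated at 17%, with a range from 8% to 28%, which means an expected step of a number 1.7 percentage points higher from compound 1 to compound 4 (within the scatter).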

Compound 4, a percentage reported as inhibition, in the whole organism at one dose (the size of the read-out at that dose, not a potency): 11.5%
Compound 4: the middle estimate sits 5.5 percentage points above what was measured; measured number inside the range.
By their numbers in this assay, from the lowest: compounds 4, 1 and 2 (each within the scatter of the next); then compound 3.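

In this assay, the exchange of 2-methoxyphenyl for 2-chlorophenyl gives a number 3.8 percentage points lower from compound 1 to compound 4 (within the scatter), and chloro in place of nitro on the same aromatic carbon gives a number 5.1 percentage points lower from compound 2 to compound 4 (within the scatter). Methoxy, nitro and chloro on this carbon, ortho to a large group, therefore all lie within the scatter of one another, where the earlier compounds offered only two of these groups, and the smaller count of heavy atoms and hydrogen-bond acceptors in chloro comes with no step beyond the scatter. No measurement is at hand that would explain why these groups read alike.

Going by these compounds, whether an amine or a carboxylic acid on this aromatic carbon would also stay within the scatter remains open. So does whether chloro on another carbon of the same ring would read the same.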